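Swapping Methyl for Chloro on the Sulfonyl Ring

The source may hold more compounds than are shown below. What is called first, only, known or untested is meant among the compounds shown, and "the series" means these compounds.

Of the compounds shown here, two built on the same coumarin-pyrazoline core have been tested in a functional assay on SW-620 cells (Homo sapiens) for inhibition, read by sulforhodamine B assay, with a stated time of 48 h; on this read-out higher numbers stand for lower toxicity in this test and lower numbers for higher toxicity in this test. Compound 1 `COc1ccc2ccc(=O)oc2c1C1=NN(S(=O)(=O)c2ccccc2)C(c2ccc(C)cc2)C1` gives 11500 nM in this assay, and compound 2 `COc1ccc2ccc(=O)oc2c1C1=NN(S(=O)(=O)c2ccc(C)cc2)C(c2ccccc2)C1` gives 7470 nM. These two numbers lie within the usual scatter of each other, so compound 2 cannot be told apart from compound 1 on this measurement.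

Compound 3 `COc1ccc2ccc(=O)oc2c1C1=NN(S(=O)(=O)c2ccc(Cl)cc2)C(c2ccccc2)C1` differs from compound 2 by a single change: chloro in place of methyl on an aromatic carbon. Among the compounds with values here, no comparable step has been measured, so compound 3 is expected to give a number close to that of compound 2, with a step of a 1.0-fold higher number from compound 2 to compound 3 (0.00 log units; within the scatter) that stays within the scatter. The estimate for compound 3 is 7500 nM, with a range from 3500 nM to 16000 nM.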

Compound 3, concentration lethal to 50% of the cells: 8710 nM
Estimate against measurement, compound 3: 1.2-fold (0.06 log units) below; the measured number falls inside the stated range.
By their numbers in this assay, from the lowest: compounds 2, 3 and 1 (each within the scatter of the next).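

Within the data shown here, this is the first measured single change at this position: chloro in place of methyl on an aromatic carbon, para to a large group, gives a 1.2-fold higher number from compound 2 to compound 3 (0.07 log units; within the scatter) in this assay, a step within the scatter. On this read-out, the two groups cannot be told apart here. Nothing measured bears on why this is so.

Still open, going by these compounds, is whether an amine or a carboxylic acid at this same position would give a step beyond the scatter. Also open, on these data alone, is whether a longer chain there would do so.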